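Trimming One Carbon From an Amide Side Chain

The source may hold more compounds than are shown below. What is called first, only, known or untested is meant among the compounds shown, and "the series" means these compounds.

Compound 1 `COc1cc2cc(C(=O)NCc3ccc(F)cc3)c(=O)oc2cc1OCCCOc1no[n+]([O-])c1S(=O)(=O)c1ccccc1` carries a 4-fluorobenzyl group on its amide-type nitrogen. For the measured compounds named here, in a functional assay on MCF7 cells (Homo sapiens) for inhibition, read by MTT assay, with a stated time of 48 h (on this read-out higher numbers stand for weaker inhibition and lower numbers for stronger inhibition), compound 1 gives 370 nM, the lowest of the three numbers known so far. Compound 2 `COc1cc2cc(C(=O)NCCCc3ccccc3)c(=O)oc2cc1OCCCOc1no[n+]([O-])c1S(=O)(=O)c1ccccc1` gives 870 nM and compound 3 `COc1cc2cc(C(=O)NCCCc3ccc(F)cc3)c(=O)oc2cc1OCCCOc1no[n+]([O-])c1S(=O)(=O)c1ccccc1` gives 600 nM; the step of a 2.4-fold higher number from compound 1 to compound 2 (0.37 log units; beyond the scatter) lies beyond the scatter, whereas a 1.6-fold higher number from compound 1 to compound 3 (0.21 log units; within the scatter) and a 1.5-fold lower number from compound 2 to compound 3 (0.16 log units; within the scatter) do not.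

Compound 4 `COc1cc2cc(C(=O)Nc3ccc(F)cc3)c(=O)oc2cc1OCCCOc1no[n+]([O-])c1S(=O)(=O)c1ccccc1` is made from compound 1 by the change (4-fluorophenyl in place of 4-fluorobenzyl on an amide-type nitrogen). Going by the values given here, both measured steps from compound 1 lengthen the chain between the amide-type nitrogen and the ring, and each raises the number; the step to compound 4 shortens that chain instead, and no measured pair covers a shortening. Those steps hint that chain length matters modestly, so a step of similar size is plausible, but its direction cannot be read from them. The expected step is a 1.4-fold higher number from compound 1 to compound 4 (0.13 log units; within the scatter). For compound 4 the expected value in this assay is 500 nM, ranging from 150 nM to 1500 nM.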

Compound 4, half-maximal inhibitory concentration: 860 nM
The estimate for compound 4 lay 1.7-fold (0.24 log units) below the measured number, and the stated range covers the measured number.
By their numbers in this assay, from the lowest: compounds 1, 3, 4 and 2 (each within the scatter of the next, the first and the last beyond it).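

Replacing 4-fluorobenzyl with 4-fluorophenyl on the amide-type nitrogen gives the first measured shortening at this position, and in this assay it does not lower the number: the result is a 2.3-fold higher number from compound 1 to compound 4 (0.37 log units; beyond the scatter). The comparisons with the longer chains are less clear-cut, since a 1.4-fold higher number from compound 3 to compound 4 (0.16 log units; within the scatter) and a 1.0-fold lower number from compound 2 to compound 4 (0.01 log units; within the scatter) both lie within the scatter, so this assay cannot separate 4-fluorophenyl from 3-(4-fluorophenyl)propyl or 3-phenylpropyl. The information available offers no measured explanation for the rise from 4-fluorobenzyl to 4-fluorophenyl.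

It remains open where a 2-(4-fluorophenyl)ethyl group on the same nitrogen would fall among these compounds. The compounds shown also leave open how a plain benzyl group would compare with 4-fluorobenzyl, and what a chain ending in an amine would do at this position.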